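Limits all round: a diethylamino-to-methylpiperidinyl swap

The source may report more compounds than this note shows. Statements on the series, on what has been measured and on what is new or still open speak of the compounds shown alone.

Compound 1 `CN(C)Cc1ccc(NC(=O)NN=C(c2ccccn2)c2ccccn2)cc1` gives in a functional assay on MCF7 cells (Homo sapiens) for antiproliferative activity, read by CCK-8 assay, with a stated time of 24 h (a higher number here means a weaker inhibitor, a lower number a stronger inhibitor), the value > 40000 nM, a limit of the assay.
Compound 2 `CCN(CC)Cc1ccc(NC(=O)NN=C(c2ccccn2)c2ccccn2)cc1` gives in this assay the value > 40000 nM, also a limit.
Compound 3 `CC1CCN(Cc2ccc(NC(=O)N/N=C/c3ccccn3)cc2)CC1` gives in this assay the value > 40000 nM, again a limit.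

Compound 2 stands at a limit, and every value shown sits at the same limit (the limit of > 40000 nM in this assay, at which 3 of the 3 values shown sit). Within the data shown here, the only measured step, a step that the two limits leave unreadable from compound 1 to compound 2, cannot be read in size. Compound 4 `CC1CCN(Cc2ccc(NC(=O)NN=C(c3ccccn3)c3ccccn3)cc2)CC1` differs from compound 2 by 4-methylpiperidin-1-yl in place of diethylamino on a saturated chain carbon bound to an aromatic carbon. Compound 3, which shares the 4-methylpiperidin-1-yl group, also gave only a limit. With no readable step to rest on, the expectation for compound 4 is a step of a number no higher from compound 2 to compound 4 (the limit leaves the size open), most likely another limit; the estimate for compound 4 is 40000 nM, within 10000 nM to 200000 nM.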

Compound 4, half-maximal inhibitory concentration: > 40000 nM
Compound 4: no number, only a limit; the forecaster's own chance of this, stated with the estimate: 85%; the middle value lies on the limit itself.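

In this assay compound 4 gives > 40000 nM, again a limit. Its steps from compound 1 and from compound 2 cannot be read in size. The compounds shown leave open how strongly any of them acts in this assay, with every value at one limit: the limit of > 40000 nM in this assay, at which 4 of the 4 values shown sit.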